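A Methyl Step Repeated on a Second Core

The compounds below may be only part of what the source reports. "The series", "measured", "known", "first", "only" and "open" are said of these compounds alone.

Compound 1 `NS(=O)(=O)c1cccc(Nc2nccc(-n3ncc4cccnc43)n2)c1`: 14600 nM
Compound 2 `NS(=O)(=O)c1ccc(Nc2nccc(-n3ncc4cccnc43)n2)cc1`: 8040 nM
Compound 3 `Cc1nn(-c2ccnc(Nc3cccc(S(N)(=O)=O)c3)n2)c2ncccc12`: 24800 nM

All three were tested in a functional assay on HCT-116 cells (Homo sapiens) for antiproliferative activity, read by MTT assay, with a stated time of 72 h; a higher number here means a weaker inhibitor of growth, a lower number a stronger inhibitor of growth. Compound 1 and compound 2 are built from the same atoms joined differently; the difference between the two cores is not broken down here. Their two numbers lie within the scatter of each other. Compound 3 differs from compound 1 by methyl in place of hydrogen on an aromatic carbon, and that change gave a 1.7-fold higher number from compound 1 to compound 3 (0.23 log units; within the scatter), a step that stays inside the scatter. Compared with compound 2, the number of compound 3 is the higher of the two and the gap lies beyond the scatter.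

Compound 4 `Cc1nn(-c2ccnc(Nc3ccc(S(N)(=O)=O)cc3)n2)c2ncccc12` has not yet been measured in this assay. It differs from compound 2 by methyl in place of hydrogen on an aromatic carbon, the same change, at the same place, that turns compound 1 into compound 3. The expected step from compound 2 to compound 4 is a 1.7-fold higher number from compound 2 to compound 4 (0.23 log units; within the scatter), and this rests on compound 1 and compound 3 having shown a 1.7-fold higher number from compound 1 to compound 3 (0.23 log units; within the scatter). For compound 4 the estimated value in this assay is 13500 nM, expected to fall between 6000 nM and 30000 nM.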

Compound 4, concentration for 50% growth inhibition: 8840 nM
Beside the measured number, compound 4's estimate is 1.5-fold (0.18 log units) above it; measured number inside the range.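

In this assay, methyl in place of hydrogen on an aromatic carbon of the second core gave a 1.1-fold higher number from compound 2 to compound 4 (0.04 log units; within the scatter), so this step, like the earlier one, stays inside the scatter. The two readings of the same change do not differ from each other: the same change on two cores in this assay, a 1.7-fold higher number (0.23 log units; within the scatter) from compound 1 to compound 3 and a 1.1-fold higher number (0.04 log units; within the scatter) from compound 2 to compound 4, 1.5-fold (0.19 log units) apart, within the scatter of two such steps. This shows that, on these two cores and in this one assay, the change carried over without a step that can be told from the scatter, but it does not show that the methyl is without effect in other assays, and two pairs of compounds give no rule for any further core.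

The compounds shown leave open whether a larger or different group at the same place, such as ethyl, an amine or chlorine, would give a step beyond the scatter. They also leave open whether the methyl step would hold if the sulfonamide gave way to a carboxylic acid.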